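A few compounds are considered here, and "the series" means these few. Any claim that something is new, unique, unknown or untested is made for them only; others in the source may bear on it.

Compound 1 `CCC[C@@H](OC(C)=O)C1=C(Br)/C(=C/Br)OC1=O` is the most potent of the compounds with a number in a functional assay on KB cells (Homo sapiens) for cytotoxicity (on this read-out higher numbers stand for an effect only at larger amounts of compound and lower numbers for an effect already at smaller amounts), where compound 1 gives 0.8 ug/mL. Compound 2 `CCCCC1=C(Br)C(OC)(C(Br)Br)OC1=O` stands next; in this assay compound 2 gives 7.6 ug/mL, a step that lies beyond the scatter. Compound 3 `CCCCC1=C(Br)/C(=C/Br)OC1=O` gives in this assay only a limit, > 20 ug/mL, not a number. That limit is the one noted in the limit of > 20 ug/mL in this assay, at which 1 of the 3 values shown sits. Within the data shown here, the one measured step that differs in a single place, an at least 25-fold higher number from compound 1 to compound 3 (1.39 log units; beyond the scatter), removes the acetoxy group altogether and is large.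

Compound 4 `CCC[C@@H](OC(C)=O)C1=C(Br)/C(=C/I)OC1=O` differs from compound 1 in another way: iodo in place of bromo on a double-bonded chain carbon bound to a double-bonded ring carbon. Among the measured compounds shown here, no measured step touches this halogen, so the step from compound 1 to compound 3 offers no guide; the change exchanges one halogen for another without altering the acetoxy group, the chain, or the core of compound 1. The expected step in this assay is therefore none beyond the scatter, no change at the digits printed from compound 1 to compound 4 (within the scatter). Compound 4 is estimated at 0.8 ug/mL, with a range from 0.3 ug/mL to 2 ug/mL.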

Compound 4, concentration for half-maximal effect: 0.1 ug/mL
Beside the measured number, compound 4's estimate is 8.0-fold (0.90 log units) above it; measured number outside the range, below it.
By their numbers in this assay, from the lowest: compound 4; then compound 1; then compound 2. At a limit, above all of these: compound 3.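

Iodo in place of bromo on a double-bonded chain carbon bound to a double-bonded ring carbon gives in this assay an 8.0-fold lower number from compound 1 to compound 4 (0.90 log units; beyond the scatter) and so counts as a modest step. Among these compounds, until this result, the only step in a single place lay at the acetoxy group, and it showed nothing about the halogen. This step shows that the number also responds to an exchange of one halogen for another at this second place, while the acetoxy group, the chain and the core of compound 1 stay the same.

On these data alone, whether chloro, fluoro or a nitrile at this place would move the number further remains open, as does whether iodo gives a similar step on a plain butyl chain without the acetoxy group. The measurements shown include none that explains this step.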